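The source may hold more compounds than are shown below. What is called first, only, known or untested is meant among the compounds shown, and "the series" means these compounds.

Compound 3 `O=c1ccoc2cc(OCc3cn(Cc4cccc([N+](=O)[O-])c4)nn3)ccc12` is one of three measured compounds sharing a core, and in a functional assay on SW480 cells (Homo sapiens) for cytotoxicity, read by MTT assay, with a stated time of 48 h (a higher number here means a weaker inhibitor, a lower number a stronger inhibitor), compound 3 gives only a limit of the assay, > 100000 nM, not a number. Compound 1 `Cc1cccc(Cn2cc(COc3ccc4c(=O)ccoc4c3)nn2)c1` gives 11700 nM in this assay. Compound 2 `O=c1ccoc2cc(OCc3cn(Cc4ccc(Cl)cc4)nn3)ccc12` likewise gives only a limit, > 100000 nM. So compound 3 stands at the weak end of what was measured, where it sits together with compound 2 at the limit of > 100000 nM in this assay, at which 2 of the 3 values shown sit.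

Compound 4 `O=c1ccoc2cc(OCc3cn(Cc4ccccc4F)nn3)ccc12` differs from compound 3 in one place: 2-fluorophenyl in place of 3-nitrophenyl on a saturated chain carbon bound to an aromatic nitrogen. The measured steps of an at least 8.5-fold higher number from compound 1 to compound 3 (0.93 log units; beyond the scatter) and an at least 8.5-fold higher number from compound 1 to compound 2 (0.93 log units; beyond the scatter) show that exchanging the 3-methylphenyl of compound 1 for either a nitro-bearing or a chlorine-bearing phenyl pushed the value to the limit, while a step that the two limits leave unreadable from compound 2 to compound 3 cannot be sized. None of these steps involves a 2-fluorophenyl, so the estimate is uncertain, and the expected step is an at least 1.4-fold lower number from compound 3 to compound 4 (0.15 log units; that floor lies within the scatter), a modest move toward a readable number or none at all. Compound 4 is therefore expected at about 70000 nM, within 15000 nM to 200000 nM.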

Compound 4, half-maximal inhibitory concentration: 11400 nM
Estimate against measurement, compound 4: 6.1-fold (0.79 log units) above; measured number below the stated range.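

Moving to 2-fluorophenyl at this position gives an at least 8.7-fold lower number from compound 3 to compound 4 (0.94 log units; beyond the scatter) and an at least 8.7-fold lower number from compound 2 to compound 4 (0.94 log units; beyond the scatter), so a phenyl here can carry a group other than methyl and still give a readable number. It also gives a 1.0-fold lower number from compound 1 to compound 4 (0.01 log units; within the scatter), which leaves 2-fluorophenyl and 3-methylphenyl indistinguishable on this position. Compound 2 and compound 3 still show an assay limit rather than a number, so among these phenyl groups a halogen alone does not settle the outcome, with the 4-chlorophenyl of compound 2 at that limit and the 2-fluorophenyl of compound 4 readable: the limit of > 100000 nM in this assay, at which 2 of the 4 values shown sit.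

The compounds shown do not separate the identity of the group on the phenyl from its place there, and the step from compound 2 to compound 3 cannot be read. Going by these compounds, an amine or a carboxylic acid on this phenyl, or a longer chain carrying it, also remains open.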